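The source may report more compounds than this note shows. Statements on the series, on what has been measured and on what is new or still open speak of the compounds shown alone.

Of the compounds shown here, two have so far been measured in a physicochemical assay for lipophilicity, measured as octanol-water partition; on this read-out lower numbers stand for lower lipophilicity and higher numbers for higher lipophilicity. Compound 1 `O=C(COc1cccc2ccccc12)N/N=C/c1ccc(Cl)cc1` gives 4.54 in this assay, the higher of the two values. Compound 2 `COc1cc(/C=N/NC(=O)COc2cccc3ccccc23)cc(OC)c1O` gives 3.23 in this assay, a gap that lies well beyond the usual scatter. Compound 3 `O=C(COc1cccc2ccccc12)N/N=C/c1ccccc1Cl` has not yet been measured. It differs from compound 1 in one place: 2-chlorophenyl in place of 4-chlorophenyl on a carbon with a double bond to nitrogen Since the same atoms are merely joined differently, the step is expected to be small, most likely none beyond the scatter: a number 0.09 log units lower from compound 1 to compound 3 (within the scatter). Compound 3 is therefore estimated at 4.45, within a range from 4.1 to 4.8.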

Compound 3, partition coefficient: 4.54
For compound 3 the middle estimate is 0.09 log units below the measured one; the range from low to high includes it.
By their numbers in this assay, from the lowest: compound 2; then compounds 1 and 3 (each within the scatter of the next).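

In this assay, putting 2-chlorophenyl in place of 4-chlorophenyl on a carbon with a double bond to nitrogen gives no change at the digits printed from compound 1 to compound 3 (within the scatter). Among these compounds, this is the first direct view of a single change at this place: for this one pair, moving the chlorine around the phenyl ring does not register on this read-out. No available evidence explains this result. Still open, on these data alone, is whether the read-out stays just as steady when an amine or a carboxylic acid stands on that phenyl ring instead of chlorine.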